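This account rests on a few compounds, and the source may have more. Where it says the series, first, only, none or still open, it means among the compounds named here.

Measured compounds:
Compound 1, `COC(=O)[C@@]1(C)CCC=C2[C@@H]1CC[C@@H](C)[C@]2(C)Cc1c(C=O)[nH]c2ccccc12`: 20000 nM
Compound 2, `COC(=O)[C@@]1(C)CC[C@@H]2C3=C1CC[C@@H](C)[C@]3(C)C[C@@H]1c3ccccc3N[C@H]21`: 50000 nM
Compound 3, `COC(=O)[C@@]1(C)CC[C@@H]2C3=C1CC[C@@H](C)[C@]3(C)C[C@@H]1c3cc(C)ccc3N[C@H]21`: 32000 nM

Compound 3 stands second highest of the three numbers in a functional assay on WiDr cells (Homo sapiens) for inhibition, read by sulforhodamine B assay, with a stated time of 48 h; on this read-out lower numbers stand for stronger inhibition of growth and higher numbers for weaker inhibition of growth. Among the compounds with values here, its nearest neighbour is compound 2, and the one step measured between them, a 1.6-fold lower number from compound 2 to compound 3 (0.19 log units; within the scatter), lies within the scatter. Within the data shown here, compound 1 gives the lowest number, but no single-change step connects it to compound 3, so only the two values themselves can be compared, and they too lie within the scatter of each other.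

Compound 4, `COC(=O)[C@@]1(C)CC[C@@H]2C3=C1CC[C@@H](C)[C@]3(C)C[C@@H]1c3cc(Br)ccc3N[C@H]21`, differs from compound 3 by bromo in place of methyl on an aromatic carbon, that is a bromo in place of a methyl on an aromatic carbon of a six-membered aromatic ring of carbon only, part of a fused or bridged system of five rings, meta to a fused ring and para to a fused ring. Among the measured compounds shown here, the only measured step bearing on this position is the one from compound 2 to compound 3, which stayed within the scatter. For the measured compounds named here, no step with a bromo has been measured here. The step from compound 3 to compound 4 is therefore expected to be small, a 1.1-fold lower number from compound 3 to compound 4 (0.06 log units; within the scatter), with no change beyond the scatter in either direction. For compound 4 the estimate in this assay is 28000 nM, with a range from 11000 nM to 70000 nM.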

Compound 4, concentration for 50% growth inhibition: 55000 nM
Estimate against measurement, compound 4: 2.0-fold (0.29 log units) below; measured number inside the range.
By their numbers in this assay, from the lowest: compounds 1, 3, 2 and 4 (each within the scatter of the next, the first and the last beyond it).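

In this assay, this aromatic carbon, para to a fused ring, now carries a third group: bromo in place of methyl gives a 1.7-fold higher number from compound 3 to compound 4 (0.24 log units; within the scatter) and bromo in place of hydrogen gives a 1.1-fold higher number from compound 2 to compound 4 (0.04 log units; within the scatter) on the same core. Together with the earlier methyl step, this places hydrogen, methyl and bromo within the scatter of one another, so the position has not yet separated any of these three groups. No measured evidence is at hand to account for these small steps.

The compounds shown leave open whether an amine, a carboxylic acid or a longer chain on this carbon would move the number beyond the scatter. They also leave open whether bromo would read the same on the other carbons of this ring.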